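Cytotoxicity notes on a methoxy-to-ethoxy change

This account rests on a few compounds, and the source may have more. Where it says the series, first, only, none or still open, it means among the compounds named here.

The series shares one core, shown in compound 1 `COc1ccc(-c2csc(Nc3ccc(Cl)cn3)n2)nc1`. Going by the values given here, in an ADME assay on KB cells (Homo sapiens) for cytotoxicity, read by MTT assay, with a stated time of 72 h (a lower number here means that less compound is tolerated, a higher number that more compound is tolerated), compound 1 gives 59600 nM, which is the only number in hand for the series. Compound 2 `COc1cccc(-c2csc(Nc3ccc(Cl)cn3)n2)n1` belongs to the same set, but in this assay compound 2 has "not determined" (no result reported), so nothing can be said of it beyond its structure. Compound 3 `CCOc1ccc(-c2csc(Nc3ccc(Cl)cn3)n2)nc1` remains to be measured in this assay.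

The change from compound 1 to compound 3 is methyl in place of hydrogen on a saturated chain carbon bound to an oxygen on an aromatic ring. Among the compounds with values here, no pair of measured compounds differs in one place only, so no measured step shows what such a change does in this assay. With nothing to go on but the value of compound 1, the expectation is a step no larger than the scatter, in no set direction. Compound 3 is expected to give 50000 nM, between 20000 nM and 120000 nM. The estimated step of a 1.2-fold lower number from compound 1 to compound 3 (0.08 log units; within the scatter) is thus expected to stay within the scatter.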

Compound 3, half-maximal cytotoxic concentration: 2700 nM
Estimate against measurement, compound 3: 19-fold (1.27 log units) above, and the stated range ends above it.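

In this assay methyl in place of hydrogen on a saturated chain carbon bound to an oxygen on an aromatic ring gives a 22-fold lower number from compound 1 to compound 3 (1.34 log units; beyond the scatter) and so marks this position as sensitive to a small change. Going from methoxy to ethoxy, a change of a single carbon, moves the series toward less compound being tolerated, by a step beyond the scatter. No measurement at hand speaks to the origin of this step.

On these data alone, the step rests on a single pair, so whether a longer chain such as propoxy or a branched chain such as isopropoxy would extend it, hold it or reverse it stays open. Also open, as far as these compounds go, is how a polar end group on the chain, such as an amine or a carboxylic acid, would read in this assay on the shared core.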